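Notes on compound 4: cyano in place of hydrogen

The source may hold more compounds than are shown below. What is called first, only, known or untested is meant among the compounds shown, and "the series" means these compounds.

compound 1 `COc1cc(C)c(-c2cccc(COc3ccc4c(c3)C(O)CC4CC(=O)O)c2)c(C)c1` in a functional assay on CHO cells for agonist activity at Free fatty acid receptor 1 (Homo sapiens), read by FLIPR and calcium flux (on this read-out higher numbers stand for an effect only at larger amounts of compound and lower numbers for an effect already at smaller amounts), gives 550 nM
compound 2 `Cc1cc(OCC2CC2)cc(C)c1-c1cccc(COc2ccc(S(=O)(=O)CC(=O)O)cc2)c1` gives 79.4 nM
compound 3 `O=C(O)CS(=O)(=O)c1ccc(OCc2cccc(-c3ccccc3)c2)cc1` gives 288 nM

Compound 3 holds the second highest number of the three. Its nearest neighbour is compound 1, whose number is higher but within the scatter, so the two are not separated. Compound 2 gives the lowest number, and the gap between compound 3 and compound 2 lies beyond the scatter. Compound 4 `N#Cc1ccccc1-c1cccc(COc2ccc(S(=O)(=O)CC(=O)O)cc2)c1` is not yet measured; it differs from compound 3 by cyano in place of hydrogen on an aromatic carbon, that is, phenyl to 2-cyanophenyl. Among the measured compounds shown here, no step between measured compounds isolates this change, and the pair compound 2 against compound 3 shows only that substitution on the phenyl can move the number beyond the scatter. For compound 4 a small drop in number is expected, a 1.4-fold lower number from compound 3 to compound 4 (0.16 log units; within the scatter), at the edge of the scatter. Compound 4 is estimated at 200 nM, within 60 nM to 650 nM.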

Compound 4, half-maximal effective concentration: 457 nM
Beside the measured number, compound 4's estimate is 2.3-fold (0.36 log units) below it, within the range that was stated.
By their numbers in this assay, from the lowest: compound 2; then compounds 3, 4 and 1 (each within the scatter of the next).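

In this assay, among the compounds shown here, the change from phenyl to 2-cyanophenyl gives the first single-place step, a 1.6-fold higher number from compound 3 to compound 4 (0.20 log units; within the scatter), and at this place cyano is not separated from hydrogen. This position therefore takes a group of this size without a step that can be read. No evidence at hand accounts for this result.

As far as these compounds go, whether an amine, a methoxy group or a carboxylic acid at this place would give a step beyond the scatter stays open. So does whether cyano would read the same on the substituted phenyl of compound 2.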